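This account rests on a few compounds, and the source may have more. Where it says the series, first, only, none or still open, it means among the compounds named here.

Working notes on the series. Two compounds have numbers in an assay on CHO cells for displacement of a labelled ligand from adenosine receptor A3 (Homo sapiens); a lower number here means a stronger inhibitor, a higher number a weaker inhibitor. Compound 1 `COc1ccc(CNc2ncc(C(=O)O)c3nc(-c4ccco4)nn23)cc1OC` gives 159 nM there. Compound 2 `Cc1ccc(CNc2ncc(C(=O)O)c3nc(-c4ccco4)nn23)cc1` gives 751 nM, the higher of the two numbers, and the gap to compound 1 lies beyond the usual scatter. Among the measured compounds shown here, no pair differing in a single place has been measured, so the two values show only that they differ.

Compound 3 `COc1ccc(CNc2ncc(C(=O)O)c3nc(-c4ccco4)nn23)cc1` has not yet been measured in this assay. It differs from compound 2 by methoxy in place of methyl on an aromatic carbon. For the measured compounds named here, compound 1, which carries a methoxy at the same place together with a second methoxy, gives 159 nM, the lower of the two known numbers. On that basis the expected step is a 2.3-fold lower number from compound 2 to compound 3 (0.37 log units; beyond the scatter), a moderate move toward a lower number, short of the full gap between the two measured compounds. Compound 3 is therefore estimated at 320 nM, with a range of 130 nM to 800 nM.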

Compound 3, inhibition constant: 5520 nM
Beside the measured number, compound 3's estimate is 17-fold (1.24 log units) below it; measured number outside the range, above it.
By their numbers in this assay, from the lowest: compound 1; then compound 2; then compound 3.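

In this assay, methoxy in place of methyl at this place, para to a large group, gives a 7.4-fold higher number from compound 2 to compound 3 (0.87 log units; beyond the scatter), so a single methoxy here does not by itself carry the low number of compound 1. Hydrogen in place of the second methoxy gives a 35-fold higher number from compound 1 to compound 3 (1.54 log units; beyond the scatter), so among these compounds the low number is seen only with both methoxy groups present, and the effect of the methoxy at this place depends on what else the aromatic ring carries. No measurement at hand accounts for either step.

The compounds shown leave open how a plain benzyl group, or a chlorine or a hydroxyl at this place, would stand against compound 2 and compound 3. They also leave open whether the second methoxy alone, without the one at this place, would hold the number of compound 1.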